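The source may hold more compounds than are shown below. What is called first, only, known or untested is meant among the compounds shown, and "the series" means these compounds.

Of the compounds shown here, three sharing one core have been tested in an assay on isolated protein for inhibition of Rho-associated protein kinase 2 (Homo sapiens); a lower number here means a stronger inhibitor, a higher number a weaker inhibitor. Compound 1 `CC(C)N[C@H](C(=O)Nc1cc2cc[nH]c(=O)c2cc1Cl)C1CCCCC1` gives 25 nM, compound 2 `N[C@H]1CC[C@H](C(=O)Nc2cc3cc[nH]c(=O)c3cc2Cl)CC1` gives 330 nM, and compound 3 `CN(C)[C@H]1CC[C@@H](C(=O)Nc2cc3cc[nH]c(=O)c3cc2Cl)CC1` gives 1000 nM. Among these three numbers compound 2 stands second highest, closer to compound 3 than to compound 1.

Compound 4 `CC(C)C[C@H](N)C(=O)Nc1cc2cc[nH]c(=O)c2cc1Cl` has not yet been measured. It differs from compound 2 in one place: 1-amino-3-methylbutyl in place of 4-aminocyclohexyl on a carbonyl carbon. For the measured compounds named here, since no pair of measured compounds shows exactly this change, the size of the step is uncertain. With compound 1 giving 25 nM, an open chain bearing the amine seems compatible with strong inhibition, so a modest move toward lower numbers is expected. Compound 4 is estimated at 150 nM in this assay, within 40 nM to 600 nM, which means an expected step of a 2.2-fold lower number from compound 2 to compound 4 (0.34 log units; beyond the scatter).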

Compound 4, half-maximal inhibitory concentration: 340 nM
The estimate for compound 4 lay 2.3-fold (0.36 log units) below the measured number; the measured number falls inside the stated range.
By their numbers in this assay, from the lowest: compound 1; then compounds 2 and 4 (each within the scatter of the next); then compound 3.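

Swapping 4-aminocyclohexyl for 1-amino-3-methylbutyl on a carbonyl carbon brings a 1.0-fold higher number from compound 2 to compound 4 (0.01 log units; within the scatter) in this assay and so leaves inhibition unchanged within the usual scatter. For this pair, then, the ring is not needed to hold this level of inhibition: the open chain serves equally well. No measurement available here bears on the reason for this match.

From the compounds shown here alone, whether the amine itself matters remains open; a 3-methylbutyl chain or a cyclohexyl ring without the amine would test this. Going by these compounds, how a longer chain carrying the amine would compare also remains open.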